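A few compounds are considered here, and "the series" means these few. Any claim that something is new, unique, unknown or untested is made for them only; others in the source may bear on it.

Of the compounds shown here, three have been measured in a physicochemical assay for lipophilicity, read by HPLC, at pH 7.5; on this read-out higher numbers stand for higher lipophilicity and lower numbers for lower lipophilicity. Compound 1 `CC[C@@H](Nc1c(C#N)c(-c2ccc(-c3cccnc3C)cc2)nc2cnccc12)C(N)=O` gives 1.9, the lowest number of the three. Compound 3 `CC[C@@H](Nc1c(C#N)c(-c2ccc(-c3cccc(C)c3F)cc2)nc2cnccc12)C(=O)O` gives 2.1, which sits within the scatter of the number for compound 1. Compound 2 `CCCCC(Nc1c(C#N)c(-c2ccc(-c3ccccc3OCC)cc2)nc2cnccc12)C(N)=O` gives 3.6, the number furthest from compound 1 and beyond the scatter. Compound 4 `CC[C@@H](Nc1c(C#N)c(-c2ccc(-c3cnccc3C)cc2)nc2cnccc12)C(N)=O` has not yet been measured in this assay. It differs from compound 1 in one place: 4-methylpyridin-3-yl in place of 2-methylpyridin-3-yl on an aromatic carbon The two compounds contain the same atoms, joined differently. Going by the values given here, no measured pair differing in only one place is available to guide this step, so the expected step is no change at the digits printed from compound 1 to compound 4 (within the scatter), none beyond the scatter. Compound 4 is therefore estimated at 1.9, within a range from 1.5 to 2.3.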

Compound 4, distribution coefficient: 2
Estimate against measurement, compound 4: 0.10 log units below; the range from low to high includes it.
By their numbers in this assay, from the lowest: compounds 1, 4 and 3 (each within the scatter of the next); then compound 2.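

Going by these compounds alone, compound 1 and compound 4 are the first pair here that differ in only one place, so this position can now be read directly. In this assay, 4-methylpyridin-3-yl in place of 2-methylpyridin-3-yl gives a number 0.10 log units higher from compound 1 to compound 4 (within the scatter), so this rearrangement of the same atoms is not separated by the read-out. Nothing measured here offers an explanation for this result.

From the compounds shown here alone, whether a larger change at this place, such as an amine or a longer chain on the pyridine in place of the methyl, would move the number stays open. One pair also cannot show whether this swap gives the same result on other versions of the core.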